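Swapping a Cyclopentylamino for an Oxadiazole Ring

The compounds below may be only part of what the source reports. "The series", "measured", "known", "first", "only" and "open" are said of these compounds alone.

Of the compounds shown here, three that share one amide core have been tested in a functional assay for antagonist activity at transient receptor potential cation channel subfamily V member 1 (Rattus norvegicus); a lower number here means a stronger inhibitor, a higher number a weaker inhibitor. Compound 1 `Cc1cccnc1-c1ccc(C(=O)Nc2ccc(F)cc2)cc1` gives only a limit of this assay, > 4000 nM, at which (the limit of > 4000 nM in this assay, at which 1 of the 3 values shown sits). Compound 2 `Cc1cccnc1-c1ccc(C(=O)Nc2ccc(Cl)cc2)cc1` gives 2020 nM in this assay. Going by the values given here, the one step measured between neighbours, an at least 1.9-fold lower number from compound 1 to compound 2 (0.29 log units; that floor lies within the scatter), is chloro in place of fluoro on an aromatic carbon. Compound 3 `CC(C)(C)c1ccc(NC(=O)c2ccc(-c3ncccc3NC3CCCC3)cc2)cc1` gives 44 nM in this assay and so stands lowest of the two numbers, with compound 2 as its nearest neighbour at a gap well beyond the scatter.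

Compound 4 `CC(C)(C)c1ccc(NC(=O)c2ccc(-c3ncccc3-c3nnco3)cc2)cc1` differs from compound 3 in one place: 1,3,4-oxadiazol-2-yl in place of cyclopentylamino on an aromatic carbon. Among the compounds with values here, the measured step concerns a different part of the shared core, so none of the measured steps bears on this change, and the data give no guide to its size or direction. The estimate for compound 4 is therefore a loose one, expected at 250 nM in this assay, between 40 nM and 2000 nM. The expected step is a 5.7-fold higher number from compound 3 to compound 4 (0.75 log units; beyond the scatter), allowing for a weaker inhibitor once the cyclopentylamino is gone.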

Compound 4, half-maximal inhibitory concentration: 59 nM
Compound 4: the middle estimate sits 4.2-fold (0.63 log units) above what was measured; low and high end bracket the measured number.
By their numbers in this assay, from the lowest: compounds 3 and 4 (each within the scatter of the next); then compound 2. At a limit, above all of these: compound 1.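

In this assay, the exchange appears as a 1.3-fold higher number from compound 3 to compound 4 (0.13 log units; within the scatter), so at this position, two atoms from the ring nitrogen, the two groups cannot be told apart. The cyclopentylamino brings a five-membered non-aromatic ring of carbon and a hydrogen-bond donor, whereas the 1,3,4-oxadiazol-2-yl is aromatic and has no donor, so neither that donor nor that non-aromatic ring is required for a value of this size in this pair. Nothing measured here accounts for the match between such different groups.

Going by these compounds alone, compounds 3 and 4 form the only one-place comparison at this position, so it remains open how a plain amine or a carboxylic acid would fare there. Compounds 1 and 2 differ from this pair in more than one place, which leaves the contribution of the position to their weaker values unresolved.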